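A few compounds are considered here, and "the series" means these few. Any claim that something is new, unique, unknown or untested is made for them only; others in the source may bear on it.

In a functional assay on PC-3 cells (Homo sapiens) for antiproliferative activity, read by MTT assay, with a stated time of 72 h (a higher number here means a weaker inhibitor, a lower number a stronger inhibitor), compound 1 `COc1cc(/C=C/C(=O)/C=C(O)/C=C/c2ccc(OC(=O)C(C)(CO)CO)c(OC)c2)ccc1OC(=O)C(C)(CO)CO` gives 3900 nM. Compound 2 `COc1cc(/C=C/C(O)=C/C(=O)/C=C/c2ccc(OC(=O)C(C)(CO)CO)c(OC)c2)ccc1O` gives 17400 nM, the higher of the two numbers and so the weaker result of this pair. Among the compounds with values here, it has hydrogen in place of (1,1-bis(hydroxymethyl)ethyl)carbonyl on an oxygen on an aromatic ring, and that change makes up the only measured step, a 4.5-fold higher number from compound 1 to compound 2 (0.65 log units; beyond the scatter).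

Compound 3 `COc1ccc(/C=C/C(O)=C/C(=O)/C=C/c2ccc(OC(=O)C(C)(CO)CO)c(OC)c2)cc1OC` alters that same free hydroxy group of compound 2, turning hydroxy to methoxy: methyl in place of hydrogen on an oxygen on an aromatic ring. The 4-hydroxy-3-methoxyphenyl group thus becomes 3,4-dimethoxyphenyl.

Within the data shown here, the step to compound 2 is the only guide, and it is a single example with a different group on that oxygen. Capping the hydroxy group with methyl might therefore recover part of that loss, so a smaller move towards a lower number is expected in this assay, possibly not clearing the scatter. The expected step is a 1.6-fold lower number from compound 2 to compound 3 (0.20 log units; within the scatter). For compound 3 the estimated value is 11000 nM, with an expected range from 4500 nM to 26000 nM.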

Compound 3, half-maximal inhibitory concentration: 7640 nM
For compound 3 the middle estimate is 1.4-fold (0.16 log units) above the measured one; measured number inside the range.
By their numbers in this assay, from the lowest: compounds 1 and 3 (each within the scatter of the next); then compound 2.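

In this assay, the free hydroxy group of compound 2 proves not to be required on this oxygen on an aromatic ring: capping it with methyl gives a 2.3-fold lower number from compound 2 to compound 3 (0.36 log units; beyond the scatter), a modest change, but one that clears the scatter. Methyl, with its single heavy atom, also does about as well here as the much larger (1,1-bis(hydroxymethyl)ethyl)carbonyl group, since a 2.0-fold higher number from compound 1 to compound 3 (0.29 log units; within the scatter) stays within the scatter, so among these three compounds the free hydroxy form alone stands apart, and no compound goes against that. Nothing measured here explains why capping this oxygen lowers the number or why two such different groups cannot be told apart.

On these data alone, what remains open is whether the effect holds for other groups on this oxygen, such as an ethyl group, a longer chain or a chain ending in an amine or a carboxylic acid. As far as these compounds go, all three compounds also keep one (1,1-bis(hydroxymethyl)ethyl)carbonyl group on the other aromatic ring, so the contribution of that group is still unknown.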